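Methoxy to hydroxy on the side ring: expected cytotoxicity

A few compounds are considered here, and "the series" means these few. Any claim that something is new, unique, unknown or untested is made for them only; others in the source may bear on it.

Two close relatives, compound 1 `COc1cc(C)cc(-c2c(-c3ccnc(-c4ccc(N(C)C)cc4)c3)cnn2CC#N)c1` and compound 2 `COc1cc(C)cc(-c2nn(CC#N)cc2-c2ccnc(-c3ccc(N(C)C)cc3)c2)c1`, have been examined in a functional assay on MDA-MB-231 cells (Homo sapiens) for cytotoxicity, read by sulforhodamine B assay, with a stated time of 48 h, tested at 100 nM; a higher number here means a weaker effect of the compound at the concentration tested, a lower number a stronger effect. In this assay compound 1 gives -5%, and in the same assay compound 2 gives 52%. Compound 2 therefore stands highest of the two numbers shown, with compound 1 as its nearest neighbour, and the gap between the two values lies beyond the usual scatter of this kind of measurement; the two structures differ in more than one place, so no single step connects them.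

Compound 3 `Cc1cc(O)cc(-c2nn(CC#N)cc2-c2ccnc(-c3ccc(N(C)C)cc3)c2)c1` has not yet been measured. It differs from compound 2 by hydrogen in place of methyl on an oxygen on an aromatic ring. Among the measured compounds shown here, no pair of measured compounds shows a step of exactly this kind, so the expectation for compound 3 rests on compound 2 alone. The change is expected to move the number in this assay only a little, if at all, and the step of a number 7 percentage points lower from compound 2 to compound 3 (within the scatter) is estimated to stay within the scatter. Compound 3 is accordingly expected to give about 45% in this assay, with a range from 15% to 75%.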

Compound 3, a percentage reported as activity, at one concentration (the size of the read-out at that concentration, not a potency): 84%
For compound 3 the middle estimate is 39 percentage points below the measured one; measured number outside the range, above it.
By their numbers in this assay, from the lowest: compound 1; then compound 2; then compound 3.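

Methoxy to hydroxy on the 3-methoxy-5-methylphenyl ring is not a silent change in this assay: it gives a number 32 percentage points higher from compound 2 to compound 3 (beyond the scatter) and so marks a clear loss of effect at the concentration tested. Among the compounds shown here, no earlier pair had isolated a change at this position, and this step shows that the single carbon of the methyl, on an oxygen on an aromatic ring, is enough to separate a compound of middling effect from one with much less. Nothing at hand explains why the number moves in this direction.

Going by these compounds, it remains open whether the step follows from the free hydroxy itself or from the loss of the methyl, a question that an ethoxy group, an amine or a fluorine atom at the same place could help to settle. Equally open, on these data alone, is whether compound 1 with -5% would respond to methoxy to hydroxy in the same way, and whether a step of this size would hold at other concentrations or in other cell lines.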